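The source may hold more compounds than are shown below. What is called first, only, known or untested is meant among the compounds shown, and "the series" means these compounds.

Measured so far:
- compound 1, `C[C@H](NC(=O)CC(F)(F)F)c1ccc(NC(=O)[C@H]2C[C@@H]2c2cccnc2)cc1`: 83.7 mL.min-1.g-1
- compound 2, `C[C@H](NC(=O)c1ccccc1)c1ccc(NC(=O)[C@H]2C[C@@H]2c2cccnc2)cc1`: 148 mL.min-1.g-1

Going by the values given here, compound 1 stands lowest of the two numbers so far in an ADME assay on microsomes from liver (Mus musculus) for pharmacokinetics (on this read-out lower numbers stand for slow clearance and higher numbers for fast clearance), and its nearest neighbour is compound 2, which gives 148 mL.min-1.g-1. Among the compounds with values here, the step of a 1.8-fold higher number from compound 1 to compound 2 (0.25 log units; within the scatter) is the only measured step, and it lies within the scatter, so these two compounds cannot be told apart on this read-out.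

Compound 3, `C[C@H](NC(=O)c1ncccn1)c1ccc(NC(=O)[C@H]2C[C@@H]2c2cccnc2)cc1`, has not yet been measured in this assay. It differs from compound 1 in one place: pyrimidin-2-yl in place of 2,2,2-trifluoroethyl on a carbonyl carbon

The step from compound 1 to compound 2 bears on this change, since it also swaps the 2,2,2-trifluoroethyl on the carbonyl carbon for a six-membered aromatic ring. That step was small, within the scatter. A second aromatic ring entering at the same place is therefore expected to give a step of similar size, most likely a somewhat higher number, though not clearly beyond the scatter: a 1.3-fold higher number from compound 1 to compound 3 (0.12 log units; within the scatter) is the expected step. For compound 3 the estimate in this assay is 110 mL.min-1.g-1, with a range from 55 mL.min-1.g-1 to 220 mL.min-1.g-1.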

Compound 3, intrinsic clearance in microsomes: 38.4 mL.min-1.g-1
Estimate against measurement, compound 3: 2.9-fold (0.46 log units) above; the measured number lies below the stated range.
By their numbers in this assay, from the lowest: compound 3; then compounds 1 and 2 (each within the scatter of the next).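

In this assay the pyrimidin-2-yl group on this carbonyl carbon gives a 2.2-fold lower number from compound 1 to compound 3 (0.34 log units; beyond the scatter) and so produces a change larger than the scatter, something the earlier step to the phenyl group did not do. The comparison between the two six-membered aromatic rings is the more telling one, with the two ring nitrogens of pyrimidin-2-yl as the difference: it shows a 3.9-fold lower number from compound 2 to compound 3 (0.59 log units; beyond the scatter) and places compound 3 clearly lowest of the three. At this position, then, the read-out depends on which aromatic ring enters and not simply on an aromatic ring being present, so the phenyl result could not stand in for every ring placed here.

No supporting measurement is available to explain why the pyrimidin-2-yl group gives the lower number. Still open, as far as these compounds go, is where other groups on this carbonyl carbon would fall, such as a pyridyl ring, which would help separate the contribution of each ring nitrogen, or a saturated ring such as morpholine, which would test whether an aromatic ring is needed at all.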